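The source may hold more compounds than are shown below. What is called first, only, known or untested is meant among the compounds shown, and "the series" means these compounds.

Working notes on the series, read in a functional assay on A2780 cells (Homo sapiens) for antiproliferative activity, read by MTT assay, with a stated time of 72 h; on this read-out higher numbers stand for weaker inhibition of growth and lower numbers for stronger inhibition of growth. Compound 3 `COc1ccc(NS(=O)(=O)/C=C/c2c(OC)cc(OC)cc2OC)cc1` gives 10 nM, the lowest number of the three measured and well clear of the other two. Compound 2 `COc1cc(OC)c(/C=C/S(=O)(=O)Nc2ccc(Cl)nc2)c(OC)c1` gives 2600 nM, and compound 1 `COc1cc(OC)c(/C=C/S(=O)(=O)Cc2cnc(Cl)cn2)c(OC)c1` gives 4760 nM. Compound 4 `COc1cc(OC)c(/C=C/S(=O)(=O)Nc2cnc(Cl)cn2)c(OC)c1` is not yet measured. It differs from compound 3 by 5-chloropyrazin-2-yl in place of 4-methoxyphenyl on a sulfonamide nitrogen. Among the measured compounds shown here, two measured steps bear on this change. Placing 4-methoxyphenyl where 6-chloropyridin-3-yl stood on that nitrogen gives a 260-fold lower number from compound 2 to compound 3 (2.41 log units; beyond the scatter), a large step. The other step, a 1.8-fold lower number from compound 1 to compound 2 (0.26 log units; within the scatter), stays within the scatter, and it links the 5-chloropyrazin-2-yl group of compound 1 to the 6-chloropyridin-3-yl group of compound 2. For the measured compounds named here, no measured compound carries 5-chloropyrazin-2-yl directly on the sulfonamide nitrogen. A large rise in the number is therefore expected, about as large as the step back from compound 3 to compound 2. The expected step is a 300-fold higher number from compound 3 to compound 4 (2.48 log units; beyond the scatter). For compound 4 the estimated value is 3000 nM, with an expected range of 1000 nM to 9000 nM.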

Compound 4, concentration for 50% growth inhibition: > 10000 nM
Compound 4: no number, only a limit; the forecaster's own chance of this, stated with the estimate: 3%; middle value at least 3.3-fold (0.52 log units) away from the limit.
By their numbers in this assay, from the lowest: compound 3; then compounds 2 and 1 (each within the scatter of the next). At a limit, above all of these: compound 4.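

In this assay, compound 4 is held only by a limit of the assay, not by a number: the limit of > 10000 nM in this assay, at which 1 of the 4 values shown sits. On the sulfonamide nitrogen, 5-chloropyrazin-2-yl in place of 4-methoxyphenyl gives an at least 1000-fold higher number from compound 3 to compound 4 (3.00 log units; beyond the scatter), while 5-chloropyrazin-2-yl in place of 6-chloropyridin-3-yl gives an at least 3.8-fold higher number from compound 2 to compound 4 (0.58 log units; beyond the scatter), so the two chlorinated groups on this nitrogen now read apart. On the sulfonyl sulfur, (5-chloropyrazin-2-yl)amino in place of (5-chloropyrazin-2-yl)methyl gives an at least 2.1-fold higher number from compound 1 to compound 4 (0.32 log units; beyond the scatter), a separation that the earlier step between a methyl-linked and an amino-linked compound, a 1.8-fold lower number from compound 1 to compound 2 (0.26 log units; within the scatter), did not show.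

From the compounds shown here alone, the full size of all three steps stays open behind the limit. Also open, going by these compounds, is whether the low number of compound 3 goes with the methoxy group or with the carbon-only ring, which a phenyl, 4-chlorophenyl or 5-methoxypyrazin-2-yl group on the sulfonamide nitrogen would help to separate.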